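The compounds below may be only part of what the source reports. "The series", "measured", "known", "first", "only" and "open" are said of these compounds alone.

Compound 1, `CCN(CC)CC(=O)Nc1ccc(-c2nc3cc(C(F)(F)F)ccc3n2C)cc1`, is one of two compounds tested in an ADME assay on Vero cells (Chlorocebus sabaeus) for cytotoxicity; a lower number here means that less compound is tolerated, a higher number that more compound is tolerated. Compound 1 gives 90000 nM. The other, compound 2, `COc1ccc(-c2nc3cc(C(C)=O)ccc3[nH]2)c(OC)c1OC`, reaches only a limit of the assay, > 100000 nM. Among the compounds with values here, compound 1 therefore holds the only numerical value, the other result being (the limit of > 100000 nM in this assay, at which 1 of the 2 values shown sits). Compound 3, `CC(=O)Nc1ccc(-c2nc3cc(C(F)(F)F)ccc3n2C)cc1`, is not yet measured; it differs from compound 1 by hydrogen in place of diethylamino on a saturated chain carbon bound to a carbonyl carbon. Within the data shown here, no measured pair shows what such a change does here, so the expected step of a 1.1-fold higher number from compound 1 to compound 3 (0.05 log units; within the scatter) is none beyond the usual scatter. Compound 3 is thus expected to give about 100000 nM, with a range from 45000 nM to 220000 nM.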

Compound 3, half-maximal cytotoxic concentration: > 100000 nM
Compound 3 ended at the assay's limit (the forecaster's own chance of this, stated with the estimate: 45%); the middle value sits exactly at the limit.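

Replacing diethylamino with hydrogen turns the side chain into acetamido, and in this assay this gives an at least 1.1-fold higher number from compound 1 to compound 3 (0.04 log units; that floor lies within the scatter). Within the data shown here, this is the first measured pair at this position, but its floor lies within the scatter, so it shows no real difference between the two compounds. The result for compound 3 is a limit, not a number: the limit of > 100000 nM in this assay, at which 2 of the 3 values shown sit.

Going by these compounds, how large the true step is stays open. The compounds shown also leave open how dimethylamino, a morpholine ring or a carboxylic acid would read at this place.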